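The source may report more compounds than this note shows. Statements on the series, on what has been measured and on what is new or still open speak of the compounds shown alone.

Measured in an ADME assay on PC-3 cells (Homo sapiens) for cytotoxicity, read by WST assay, tested at 100 uM; a lower number here means less inhibition, a higher number more inhibition at the concentration tested (going by the name of the read-out): compound 1 `O=C(Nc1ccc(Cl)cc1)C1CCCN(C(=O)c2cccc(-c3nccs3)c2)C1` gives 32%, compound 2 `O=C(Nc1cccc(Oc2ccccc2)c1)C1CCCN(C(=O)c2cccc(-c3ccco3)c2)C1` gives 0%, and compound 3 `O=C(Nc1ccc(Cl)cc1)C1CCCN(C(=O)c2cccc(-c3cccs3)c2)C1` gives 4%.

Among these three numbers compound 3 stands second highest; its value and that of compound 2 lie within the scatter of each other, while compound 1 is set apart by the step of a number 28 percentage points lower from compound 1 to compound 3 (beyond the scatter). Compound 4 `COCc1cccc(C(=O)N2CCCC(C(=O)Nc3ccc(Cl)cc3)C2)c1` differs from compound 3 in one place: methoxymethyl in place of thiophen-2-yl on an aromatic carbon. For the measured compounds named here, no measured step exchanges an aromatic ring for a short open chain; the only known step, from one five-membered ring to another, is the modest one just described and does not bear directly on this change. Compound 4 is therefore expected to stay near compound 3, with a step of a number 1 percentage points higher from compound 3 to compound 4 (within the scatter) within the scatter, and its estimated value is 5%, ranging from 0% to 20%.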

Compound 4, a percentage reported as inhibition, at one concentration (the size of the read-out at that concentration, not a potency): 0%
Compound 4: the middle estimate sits 5 percentage points above what was measured, within the range that was stated.
By their numbers in this assay, from the lowest: compounds 2, 4 and 3 (each within the scatter of the next); then compound 1.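

In this assay there is a number 4 percentage points lower from compound 3 to compound 4 (within the scatter), so at this aromatic carbon, meta to a large group, an open methoxymethyl chain and a thiophen-2-yl ring cannot be told apart. For the compounds shown here, there is also a number 32 percentage points lower from compound 1 to compound 4 (beyond the scatter), which leaves 1,3-thiazol-2-yl as the only one of these three groups here that gives a clearly higher number. No evidence is available to explain this difference. The compounds shown leave open whether an amine, a carboxylic acid or a longer chain at this carbon would give a number nearer that of compound 1.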